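Moving the Hydroxy Group in a Hydrazone Series

The source may hold more compounds than are shown below. What is called first, only, known or untested is meant among the compounds shown, and "the series" means these compounds.

Going by the values given here, compound 2 `O=C(CSc1nnc(-c2ccncc2)o1)N/N=C/c1ccc(O)cc1` gives 5510 nM in a functional assay on HepG2 cells (Homo sapiens) for cytotoxicity, read by MTT assay, with a stated time of 48 h (a lower number here means a stronger inhibitor, a higher number a weaker inhibitor), the lowest of the two numbers measured so far. Compound 1 `O=C(CSc1nnc(-c2ccncc2)o1)N/N=C/c1ccc(F)cc1` gives 12300 nM in this assay. Among the compounds with values here, the only measured step, a 2.2-fold lower number from compound 1 to compound 2 (0.35 log units; beyond the scatter), swaps one group for another. Compound 3 `O=C(CSc1nnc(-c2ccncc2)o1)N/N=C/c1ccccc1O` differs from compound 2 by 2-hydroxyphenyl in place of 4-hydroxyphenyl on a carbon with a double bond to nitrogen. Within the data shown here, no measured step moves the hydroxy group around its ring, so that earlier step offers no direct guide, and no change beyond the scatter is expected. Compound 3 is therefore estimated at 5500 nM, within 2500 nM to 12000 nM. The expected step is a 1.0-fold lower number from compound 2 to compound 3 (0.00 log units; within the scatter).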

Compound 3, half-maximal inhibitory concentration: 3510 nM
For compound 3 the middle estimate is 1.6-fold (0.20 log units) above the measured one; measured number inside the range.
By their numbers in this assay, from the lowest: compounds 3 and 2 (each within the scatter of the next); then compound 1.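

Moving the hydroxy group, with the step being a 1.6-fold lower number from compound 2 to compound 3 (0.20 log units; within the scatter) in this assay, does not separate the two placements, so on this evidence the number does not depend on which of these two hydroxyphenyl groups is present. The other comparison, a 3.5-fold lower number from compound 1 to compound 3 (0.54 log units; beyond the scatter), shows that 2-hydroxyphenyl, like 4-hydroxyphenyl, stands apart from 4-fluorophenyl by more than the scatter. Nothing shown here explains these numbers. On these data alone, whether the hydrogen of the hydroxy group matters stays open, since a methoxy group would be needed to test that. How an amine in the same place would compare is also unknown.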